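Notes toward compound 4: aryl change at the sulfonyl sulfur

The source may report more compounds than this note shows. Statements on the series, on what has been measured and on what is new or still open speak of the compounds shown alone.

Measured so far:
Compound 1, `O=S(=O)(Nc1ccc2oc(-c3ccccc3)nc2c1)c1cccc(C(F)(F)F)c1`. In an assay on cells for inhibition of HSP60/HSP10 (Homo sapiens), with a stated time of 60 min (on this read-out lower numbers stand for stronger inhibition and higher numbers for weaker inhibition), compound 1 gives > 100000 nM, a limit of the assay.
Compound 2, `COc1cccc(S(=O)(=O)Nc2ccc3oc(-c4ccccc4)nc3c2)c1`. In this assay compound 2 gives > 100000 nM, again a limit of the assay.
Compound 3, `COc1cccc(S(=O)(=O)Nc2ccc(-c3nc4ccccc4o3)cc2)c1`. In this assay compound 3 gives 80000 nM.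

Compound 2 therefore stands at the limit of this assay and has no number of its own. For the measured compounds named here, the only measured step, a step that the two limits leave unreadable from compound 1 to compound 2, runs between two limits and its size cannot be read, because of the limit of > 100000 nM in this assay, at which 2 of the 3 values shown sit. Going by the values given here, compound 3 is the one member with a number, and its arrangement of the shared core differs from compound 2 in more than one place, so no step is computed between them; the two values show only that compound 3 returns a number where compound 2 returns a limit.

Compound 4, `COc1ccc(Cl)cc1S(=O)(=O)Nc1ccc2oc(-c3ccccc3)nc2c1`, is not yet measured. It differs from compound 2 by 5-chloro-2-methoxyphenyl in place of 3-methoxyphenyl on a sulfonyl sulfur. Among the compounds with values here, no measured step touches this kind of change, so the expectation rests on compound 2 alone, which sits at the limit of this assay. The step of a number no higher from compound 2 to compound 4 (the limit leaves the size open) is expected to be none beyond the scatter. Compound 4 is estimated at 100000 nM, within 30000 nM to 300000 nM, with a fair chance that only a limit is reported.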

Compound 4, half-maximal inhibitory concentration: > 100000 nM
Compound 4 was reported as a limit; the forecaster's own chance of this, stated with the estimate: 55%; the middle value lies on the limit itself.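

No step can be read between compound 2 and compound 4, because both are reported only as limits in this assay: the limit of > 100000 nM in this assay, at which 3 of the 4 values shown sit.

The compounds shown leave open whether any aryl group on the sulfonyl sulfur gives the core of compound 2 a measurable value in this assay, and how such aryl groups would rank.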